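Aryl ring in place of dimethylcarbamoyl at the ethenyl terminus

This account rests on a few compounds, and the source may have more. Where it says the series, first, only, none or still open, it means among the compounds named here.

Working notes on the series. Compound 1, `COC(=O)/C=C/c1cccc(N(Cc2ccc(-c3ccc(OC)cc3)cc2)C(=O)C2CCCCC2)c1`, carries 4-methoxyphenyl on the benzyl ring; in an assay on isolated protein with Bile acid receptor (Homo sapiens) as the target (a higher number here means that more compound is needed for the effect, a lower number that less compound is needed), compound 1 gives 89 nM. Compound 2, `COC(=O)/C=C/c1cccc(N(Cc2ccc(/C=C/C(=O)N(C)C)cc2)C(=O)C2CCCCC2)c1`, has 2-(dimethylcarbamoyl)ethenyl in its place. In this assay compound 2 gives no number, only a limit, > 1000 nM, and it stands at the limit of > 1000 nM in this assay, at which 1 of the 2 values shown sits. The step of an at least 11-fold higher number from compound 1 to compound 2 (1.05 log units; beyond the scatter) is thus beyond the scatter, with an aromatic ring removed from the benzyl position.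

Compound 3, `COC(=O)/C=C/c1cccc(N(Cc2ccc(/C=C/c3cccc(Cl)c3)cc2)C(=O)C2CCCCC2)c1`, is the next step: 3-chlorophenyl in place of dimethylcarbamoyl on a double-bonded chain carbon bound to a double-bonded chain carbon. Among the compounds with values here, the only measured step that bears on it is the one from compound 1 to compound 2, which was large and in the losing direction; compound 3 restores a six-membered aromatic ring at the end of the ethenyl chain, while keeping the ethenyl link that compound 1 lacks. The expected step, an at least 5.0-fold lower number from compound 2 to compound 3 (0.69 log units; beyond the scatter), points back toward compound 1. Its size is uncertain, since compound 2 stands only at a limit. Compound 3 is estimated at 200 nM, within 50 nM to 1500 nM.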

Compound 3, half-maximal effective concentration: 165 nM
The estimate for compound 3 lay 1.2-fold (0.08 log units) above the measured number; measured number inside the range.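

In this assay, the ethenyl link alone does not account for the loss seen in compound 2: with 3-chlorophenyl in place of dimethylcarbamoyl on a double-bonded chain carbon bound to a double-bonded chain carbon, the step is an at least 6.0-fold lower number from compound 2 to compound 3 (0.78 log units; beyond the scatter). Setting 2-(3-chlorophenyl)ethenyl in place of 4-methoxyphenyl on an aromatic carbon gives a 1.9-fold higher number from compound 1 to compound 3 (0.27 log units; within the scatter), so these two groups, each ending in a six-membered aromatic ring, cannot be told apart in this assay, with or without the ethenyl link. Compound 2 still gives only a limit of the assay, not a number, so the full size of the step from it cannot be read: the limit of > 1000 nM in this assay, at which 1 of the 3 values shown sits.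

The change from dimethylcarbamoyl to 3-chlorophenyl alters the ring and the chlorine together, so the compounds shown do not separate the contribution of the aromatic ring from that of the chlorine, and an unsubstituted phenyl at the ethenyl terminus would be needed to do so. Also open, as far as these compounds go, is how a saturated ring such as cyclohexyl, a basic amine or a carboxylic acid would fare at that terminus, and whether a longer chain in place of the ethenyl link would hold the value.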